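The source may hold more compounds than are shown below. What is called first, only, known or untested is meant among the compounds shown, and "the series" means these compounds.

Compound 1 `CCC/N=C(\NC#N)Nc1cccnc1` and compound 2 `CCC(C)/N=C(\NC#N)Nc1cccnc1` share a core; compound 3 `CCC(C)(CC)/N=C(\NC#N)Nc1cccnc1` and compound 4 `CCC(CC)(CC)/N=C(\NC#N)Nc1cccnc1` share another, and the difference between the two cores is 1-ethyl-1-methylpropyl in place of propyl on a double-bonded nitrogen. In a functional assay on the whole organism (blood, strain Wistar-Okamoto) with Rattus norvegicus as the target, with a stated time of 5 days (on this read-out higher numbers stand for an effect only at larger amounts of compound and lower numbers for an effect already at smaller amounts), compound 1 gives 20 mg/kg, compound 2 gives 20 mg/kg and compound 3 gives 0.5 mg/kg. The step of a 40-fold lower number from compound 1 to compound 3 (1.60 log units; beyond the scatter) and the step of a 40-fold lower number from compound 2 to compound 3 (1.60 log units; beyond the scatter) are both large. The change methyl in place of hydrogen on a saturated chain carbon bound to a double-bonded nitrogen and a saturated chain carbon gave the step of no change at the digits printed from compound 1 to compound 2 (within the scatter). The change methyl in place of hydrogen on a saturated chain carbon, two bonds along the chain from a double-bonded nitrogen is the same kind of change, but its place differs: in compound 1 it sits on a saturated chain carbon bound to a double-bonded nitrogen and a saturated chain carbon, in compound 3 on a saturated chain carbon, two bonds along the chain from a double-bonded nitrogen. Compound 4 is not yet measured. For compound 4 a step of no change at the digits printed from compound 3 to compound 4 (within the scatter) is expected in this assay, resting on the small step of no change at the digits printed from compound 1 to compound 2 (within the scatter) of the same kind of change. Compound 4 is estimated at 0.5 mg/kg, with a range from 0.15 mg/kg to 1.5 mg/kg.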

Compound 4, minimum effective dose: 1 mg/kg
The estimate for compound 4 lay 2.0-fold (0.30 log units) below the measured number; the measured number falls inside the stated range.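

In this assay, methyl in place of hydrogen on a saturated chain carbon, two bonds along the chain from a double-bonded nitrogen, gives a 2.0-fold higher number from compound 3 to compound 4 (0.30 log units; within the scatter). Set beside the same kind of change on the other core, the step carries over without a difference that can be told from scatter: the same change on two cores in this assay, no change at the digits printed (within the scatter) from compound 1 to compound 2 and a 2.0-fold higher number (0.30 log units; within the scatter) from compound 3 to compound 4, 2.0-fold (0.30 log units) apart, within the scatter of two such steps. This rests on a single pair per core, with the methyl in a different place on each, so it shows agreement for these two cores only and establishes no rule for other cores.

Still open, going by these compounds, is how a longer chain in that place would read. On these data alone, a cyclohexyl group on the double-bonded nitrogen also remains open.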